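This account rests on a few compounds, and the source may have more. Where it says the series, first, only, none or still open, it means among the compounds named here.

Measured compounds in an ADME assay on HEK293 cells (Homo sapiens) for cytotoxicity, read by CellTiter-Glo and resazurin assay, with a stated time of 72 h; a higher number here means that more compound is needed for the effect, a lower number that less compound is needed:
Compound 1 `CC(=O)c1cccc(-c2ccc(C(=O)N(Cc3cccc(OCCCCCC(=O)O)c3)C(C)C)cc2)c1`; compound 1 gives > 26000 nM, which is a limit of the assay.
Compound 2 `CC(C)COc1cccc(-c2ccc(C(=O)N(Cc3cccc(OCCCCCC(=O)O)c3)C(C)C)cc2)c1`; compound 2 gives > 26000 nM, also a limit of the assay.
Compound 3 `CCOC(=O)CCCCCOc1cccc(CN(C(=O)c2ccc(-c3cccc(C(C)=O)c3)cc2)C(C)C)c1`; compound 3 gives > 26000 nM, again a limit of the assay.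

The change isobutoxy in place of acetyl on an aromatic carbon gives a step that the two limits leave unreadable from compound 1 to compound 2. The change ethyl in place of hydrogen on an oxygen next to a carbonyl group gives a step that the two limits leave unreadable from compound 1 to compound 3 and is also how the core of compound 3 differs from the core of compound 1. Compound 4 `CCOC(=O)CCCCCOc1cccc(CN(C(=O)c2ccc(-c3cccc(OCC(C)C)c3)cc2)C(C)C)c1` is not yet measured and carries the same change, (isobutoxy in place of acetyl on an aromatic carbon), on the core of compound 3. For the measured compounds named here, because of the limit of > 26000 nM in this assay, at which 3 of the 3 values shown sit, no measured step in this assay can be sized. The step from compound 3 to compound 4 is expected to be a step that the limit leaves unreadable from compound 3 to compound 4, set beside a step that the two limits leave unreadable from compound 1 to compound 2, and this rests on (the limit of > 26000 nM in this assay, at which 3 of the 3 values shown sit). Compound 4 is estimated at 40000 nM, with a range from 20000 nM to 120000 nM, most likely reported again only as a limit.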

Compound 4, half-maximal effective concentration: > 26000 nM
Compound 4: only a limit was reported; the forecaster's own chance of this, stated with the estimate: 85%; the middle value does not contradict the limit.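

For the compounds shown here, compound 4 gives > 26000 nM as a limit, and no step from compound 2 or compound 3 to compound 4 can be read: the limit of > 26000 nM in this assay, at which 4 of the 4 values shown sit. Still open is how large either change is, and at what concentration any of these compounds reaches its half-maximal effect.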